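Catechol benzamide cytotoxicity in macrophages: an estimate

The source may report more compounds than this note shows. Statements on the series, on what has been measured and on what is new or still open speak of the compounds shown alone.

The measured compounds are:
Compound 1, `O=C(Nc1cc(C(F)(F)F)cc(C(F)(F)F)c1)c1ccccc1`: in an ADME assay on cells (Macrophage, Mus musculus) for cytotoxicity, read by resazurin assay, with a stated time of 3 days (on this read-out higher numbers stand for weaker inhibition and lower numbers for stronger inhibition), compound 1 is "not determined" (no result reported).
Compound 2, `O=C(Nc1cc(C(F)(F)F)cc(C(F)(F)F)c1)c1cc(-n2cccc2)ccc1O`: in this assay compound 2 gives 3100 nM.
Compound 3, `O=C(Nc1cc(C(F)(F)F)cc(C(F)(F)F)c1)c1cc(Cl)cc(Cl)c1O`: in this assay compound 3 reaches only the assay limit of > 60000 nM.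

Compound 1 therefore stands nowhere on the numbers shown; no result is reported for it, and one of the three entries, that of compound 3, is a limit rather than a number (the limit of > 60000 nM in this assay, at which 1 of the 3 values shown sits). Among the measured compounds shown here, compound 2 is the only compound with a numerical value. Compound 4, `O=C(Nc1cc(C(F)(F)F)cc(C(F)(F)F)c1)c1cccc(O)c1O`, differs from compound 1 by 2,3-dihydroxyphenyl in place of phenyl on a carbonyl carbon. For the measured compounds named here, since no step between measured compounds is available, the expected size of the change from compound 1 to compound 4 in this assay cannot be taken from a comparison; it is expected to stay in the direction of weak inhibition, in line with the limit seen for compound 3, > 60000 nM. Compound 4 is accordingly estimated at 40000 nM, within a range from 8000 nM to 150000 nM.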

Compound 4, half-maximal inhibitory concentration: 1700 nM
For compound 4 the middle estimate is 24-fold (1.37 log units) above the measured one; measured number below the stated range.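

No step can be read for compound 4, as the compound it is set against, compound 1, stands at "not determined" (no result reported) in this assay. The compounds shown leave open what the exchange of phenyl for 2,3-dihydroxyphenyl alone does to the read-out in this assay.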